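Changing the aryl group on the amide side chain

The compounds below may be only part of what the source reports. "The series", "measured", "known", "first", "only" and "open" are said of these compounds alone.

Compound 1, `O=C(O)C[C@H](O)C[C@H](O)CCn1c(-c2ccc(F)cc2)nc(C(=O)NCc2ccccc2F)c1C1CC1`, gives 1.5 nM in an assay on microsomes from liver for inhibition of 3-hydroxy-3-methylglutaryl-coenzyme A reductase (Rattus norvegicus), read by scintillation counting, with stated times of 0.5 h and 0.75 h; a lower number here means a stronger inhibitor, a higher number a weaker inhibitor.
Compound 2, `Cc1ccc(CNC(=O)c2nc(-c3ccc(F)cc3)n(CC[C@@H](O)C[C@@H](O)CC(=O)O)c2C2CC2)cc1`, gives 1.7 nM in this assay.
Compound 3, `O=C(O)C[C@H](O)C[C@H](O)CCn1c(-c2ccc(F)cc2)nc(C(=O)NCc2ccc(F)c(F)c2)c1C1CC1`, gives 1.2 nM in this assay.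

Compound 3 has the lowest of the three numbers, yet the gaps to the others, a 1.3-fold lower number from compound 1 to compound 3 (0.10 log units; within the scatter) and a 1.4-fold lower number from compound 2 to compound 3 (0.15 log units; within the scatter), both sit within the scatter, so the three compounds cannot be told apart on these values. Compound 4, `COc1cccc(CNC(=O)c2nc(-c3ccc(F)cc3)n(CC[C@@H](O)C[C@@H](O)CC(=O)O)c2C2CC2)c1`, differs from compound 3 in one place: 3-methoxyphenyl in place of 3,4-difluorophenyl on a saturated chain carbon bound to an amide-type nitrogen. Every measured step here changes that same aryl group and stays within the scatter: a 1.1-fold higher number from compound 1 to compound 2 (0.05 log units; within the scatter), a 1.3-fold lower number from compound 1 to compound 3 (0.10 log units; within the scatter), and a 1.4-fold lower number from compound 2 to compound 3 (0.15 log units; within the scatter). A methyl group, one fluorine or two fluorines on that ring all left the number essentially unchanged, so a methoxy group in that place is expected to do the same, with no step beyond the scatter in this assay, which is the expectation behind a 1.5-fold higher number from compound 3 to compound 4 (0.18 log units; within the scatter). Compound 4 is therefore estimated at 1.8 nM, with a likely range from 0.8 nM to 4 nM.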

Compound 4, half-maximal inhibitory concentration: 1.2 nM
Beside the measured number, compound 4's estimate is 1.5-fold (0.18 log units) above it, and the stated range covers the measured number.
By their numbers in this assay, from the lowest: compounds 3, 4, 1 and 2 (each within the scatter of the next).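

Among the compounds shown here, compound 4 is the first compound here with oxygen in the group on this ring: 3-methoxyphenyl counts 1 hydrogen-bond acceptor where 3,4-difluorophenyl counts 0, and the step still reads (no change at the digits printed from compound 3 to compound 4 (within the scatter)). The other two new steps agree (a 1.4-fold lower number from compound 2 to compound 4 (0.15 log units; within the scatter); a 1.3-fold lower number from compound 1 to compound 4 (0.10 log units; within the scatter)), so all four aryl groups on this saturated chain carbon bound to an amide-type nitrogen remain indistinguishable in this assay. The tolerated change at this position therefore extends beyond methyl and fluorine to a methoxy group.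

No measurement offered here explains why these numbers stay so close. From the compounds shown here alone, all four groups carry an aromatic ring of carbon only and no net charge, so it remains open whether an amine, a carboxylic acid or a longer chain at this position would keep the number within the scatter.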